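Swapping Methyl for Fluoro on an Aromatic Ring

The source may report more compounds than this note shows. Statements on the series, on what has been measured and on what is new or still open speak of the compounds shown alone.

Of the compounds shown here, three sharing one core have been measured in a functional assay on CaEs17 cells (Homo sapiens) for cytotoxicity, read by MTT assay, with a stated time of 72 h; a higher number here means a weaker inhibitor, a lower number a stronger inhibitor. There, compound 1 `C=C1C(=O)[C@@]23C(=O)OC[C@]4([C@@H](OC(C)=O)CCC(C)(C)[C@H]4C=O)[C@@H]2CC[C@@H]1[C@H]3O` gives 72600 nM, compound 2 `C=C1C(=O)[C@@]23C(=O)OC[C@]4(C(=O)CCC(C)(C)[C@H]4C=O)[C@@H]2CC[C@@H]1[C@H]3OC(=O)c1ccccc1` gives 1710 nM, and compound 3 `C=C1C(=O)[C@@]23C(=O)OC[C@]4(C(=O)CCC(C)(C)[C@H]4C=O)[C@@H]2CC[C@@H]1[C@H]3OC(=O)c1ccc(C)cc1` gives 1050 nM. Compound 3 shares the low end of this small set with compound 2, the two lying within the scatter of each other, while compound 1 stands far from compound 3, beyond the scatter.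

The next molecule, compound 4 `C=C1C(=O)[C@@]23C(=O)OC[C@]4(C(=O)CCC(C)(C)[C@H]4C=O)[C@@H]2CC[C@@H]1[C@H]3OC(=O)c1ccc(F)cc1`, differs from compound 3 in a single group: fluoro in place of methyl on an aromatic carbon. Fluoro takes the place of methyl on an aromatic carbon, para to a large group.

Among the compounds with values here, only one measured step bears on this change: a 1.6-fold lower number from compound 2 to compound 3 (0.21 log units; within the scatter), where a methyl group is added to the aromatic ring. Within the data shown here, that step was small, but it says nothing direct about fluoro, and no fluoro compound has yet been measured. Going by the step of a 1.6-fold lower number from compound 2 to compound 3 (0.21 log units; within the scatter), no change beyond the scatter is expected in this assay, and no firm direction can be given. The estimated step is a 1.3-fold higher number from compound 3 to compound 4 (0.12 log units; within the scatter). For compound 4 the expected value is 1400 nM, with an estimated range from 700 nM to 2800 nM.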

Compound 4, half-maximal inhibitory concentration: 8310 nM
Compound 4: middle estimate off by 5.9-fold (0.77 log units), on the low side, outside the stated range (above it).
By their numbers in this assay, from the lowest: compounds 3 and 2 (each within the scatter of the next); then compound 4; then compound 1.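

In this assay, within the data shown here, this place on the aromatic ring turns out to matter, which the earlier compounds could not show: fluoro in place of methyl gives a 7.9-fold higher number from compound 3 to compound 4 (0.90 log units; beyond the scatter) and so a weaker compound, and fluoro in place of hydrogen gives a 4.9-fold higher number from compound 2 to compound 4 (0.69 log units; beyond the scatter) in the same direction. Before this, the only change at this place was methyl in place of hydrogen, a 1.6-fold lower number from compound 2 to compound 3 (0.21 log units; within the scatter) in size, and that step left open whether the ring position responded to substitution at all. Now hydrogen and methyl sit together within the scatter while fluoro stands apart from both, so a swap of one heavy atom for another can move the number beyond the scatter, and nothing available explains why fluoro behaves differently here.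

Going by these compounds, what remains open is whether this loss belongs to fluoro alone or would also appear with other groups at the same place, such as chloro, methoxy, an amine or a carboxylic acid. The three aromatic groups shown, hydrogen, methyl and fluoro, are too few to reveal any trend that would predict how those groups would read.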